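The source may report more compounds than this note shows. Statements on the series, on what has been measured and on what is new or still open speak of the compounds shown alone.

In a functional assay on SGC-7901 cells (Homo sapiens) for inhibition, read by MTT assay, with a stated time of 24 h (a higher number here means a weaker inhibitor, a lower number a stronger inhibitor), compound 1 `CC1(C)[C@H]2CC[C@]1(C)N(Cc1cn(-c3cccc(Cl)c3)nn1)C(=O)C2` gives 510 nM and compound 2 `CC1(C)[C@H]2CC[C@]1(C)N(Cc1cn(-c3cccc(O)c3)nn1)C(=O)C2` gives 270 nM. Within the data shown here, these are the only two numbers so far and they lie within the scatter of each other, so compound 2 cannot be ranked above compound 1. Compound 3 `CC1(C)[C@H]2CC[C@]1(C)N(Cc1cn(-c3cccc(Br)c3)nn1)C(=O)C2` carries bromo in place of hydroxy on an aromatic carbon. Among the measured compounds shown here, the one measured step bearing on this is a 1.9-fold lower number from compound 1 to compound 2 (0.28 log units; within the scatter), which replaced chloro with hydroxy. Read backwards, with bromo standing in for chloro, it suggests no change beyond the scatter, if anything towards a higher number. The expected step is a 1.7-fold higher number from compound 2 to compound 3 (0.22 log units; within the scatter). For compound 3 the estimated value is 450 nM, with an expected range from 190 nM to 1000 nM.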

Compound 3, half-maximal inhibitory concentration: 120 nM
Estimate against measurement, compound 3: 3.8-fold (0.57 log units) above; the whole stated range lies above it.
By their numbers in this assay, from the lowest: compound 3; then compounds 2 and 1 (each within the scatter of the next).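

Replacing hydroxy with bromo now gives a step beyond the scatter (a 2.3-fold lower number from compound 2 to compound 3 (0.35 log units; beyond the scatter)), and so does replacing chloro with bromo (a 4.3-fold lower number from compound 1 to compound 3 (0.63 log units; beyond the scatter)). This position therefore responds to the group placed on it, which the first pair could not show, and bromo gives the lowest number of the three, though both steps are modest. Nothing measured here accounts for these steps. From the compounds shown here alone, how iodo, methyl, an amine or a carboxylic acid at this position would compare with bromo remains open.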